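A few compounds are considered here, and "the series" means these few. Any claim that something is new, unique, unknown or untested is made for them only; others in the source may bear on it.

Measured compounds:
- Compound 1, `O=c1cc(CC(COCc2ccccc2)COCc2ccccc2)[nH]c(=O)[nH]1`: in a functional assay on MIA PaCa-2 cells (Homo sapiens) for antiproliferative activity, read by MTT assay, with a stated time of 72 h (on this read-out lower numbers stand for stronger inhibition and higher numbers for weaker inhibition), compound 1 gives > 100000 nM, which is a limit of the assay rather than a number.
- Compound 2, `COCn1c(CC(COCc2ccccc2)COCc2ccccc2)cc(=O)[nH]c1=O`: compound 2 gives > 100000 nM, likewise a limit.

Compound 2 thus stands at the limit, where both shown values sit (the limit of > 100000 nM in this assay, at which 2 of the 2 values shown sit). Going by the values given here, the single measured step, a step that the two limits leave unreadable from compound 1 to compound 2, cannot be read. Compound 3, `COCn1c(CC(COCc2ccccc2)COCc2ccccc2)c(C)c(=O)[nH]c1=O`, differs from compound 2 by methyl in place of hydrogen on an aromatic carbon. Among the compounds with values here, no measured step speaks to this change, so compound 3 is expected to stay near the limit, with a step that the limit leaves unreadable from compound 2 to compound 3 that is expected to be unreadable. Compound 3 is estimated at 150000 nM, within 40000 nM to 500000 nM.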

Compound 3, half-maximal inhibitory concentration: 55900 nM
Beside the measured number, compound 3's estimate is 2.7-fold (0.43 log units) above it, and the stated range covers the measured number.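

Methyl in place of hydrogen on this aromatic carbon gives the only compound shown with a readable number in this assay, while the other two remain at a limit: the limit of > 100000 nM in this assay, at which 2 of the 3 values shown sit. The change reads as an at least 1.7-fold lower number from compound 2 to compound 3 (0.25 log units; that floor lies within the scatter) and this is a floor for its size, not an exact size. So this position can tolerate an added methyl without any measured loss of activity.

From the compounds shown here alone, whether an ethyl group, a longer chain or an amine on the same carbon would move the number further stays open. Also open, going by these compounds, is whether methyl gives a readable number without the methoxymethyl group on the ring nitrogen.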